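The source may report more compounds than this note shows. Statements on the series, on what has been measured and on what is new or still open speak of the compounds shown alone.

Compound 1 `CN(C)CCn1cnnc1-c1cc(Oc2ccc(NC(=O)N/N=C/c3ccc(F)cc3F)cc2F)ccn1` gives 1900 nM in a functional assay on U-87MG ATCC cells (Homo sapiens) for cytotoxicity, read by MTT assay, with a stated time of 72 h; a higher number here means a weaker inhibitor, a lower number a stronger inhibitor.
Compound 2 `CN(C)CCn1cnnc1-c1cc(Oc2ccc(NC(=O)N/N=C/c3c(O)ccc4ccccc34)cc2F)ccn1` gives 620 nM in this assay.
Compound 3 `CN(C)CCn1cnnc1-c1cc(Oc2ccc(NC(=O)N/N=C/c3ccc(O)cc3)cc2F)ccn1` gives 7750 nM in this assay.

Among these three numbers compound 1 stands second highest. Its nearest neighbour is compound 2, reached by a step beyond the scatter, a 3.1-fold lower number from compound 1 to compound 2 (0.49 log units; beyond the scatter); its furthest is compound 3, also beyond the scatter, a 4.1-fold higher number from compound 1 to compound 3 (0.61 log units; beyond the scatter). The two hydroxylated aryl groups themselves lie far apart, a 13-fold higher number from compound 2 to compound 3 (1.10 log units; beyond the scatter).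

Compound 4 `CN(C)CCn1cnnc1-c1cc(Oc2ccc(NC(=O)N/N=C/c3ccc(O)cc3O)cc2F)ccn1` has not yet been measured in this assay. It differs from compound 1 in one place: 2,4-dihydroxyphenyl in place of 2,4-difluorophenyl on a carbon with a double bond to nitrogen. Going by the values given here, two measured steps bear on this change. Replacing 2,4-difluorophenyl by 4-hydroxyphenyl raised the number, a 4.1-fold higher number from compound 1 to compound 3 (0.61 log units; beyond the scatter), whereas replacing it by 2-hydroxynaphthalen-1-yl lowered it, a 3.1-fold lower number from compound 1 to compound 2 (0.49 log units; beyond the scatter). The incoming 2,4-dihydroxyphenyl shares a hydroxyl with each of those groups, so the two precedents pull in opposite directions and neither is a clean match. On balance a modest step toward a higher number is expected, a 1.6-fold higher number from compound 1 to compound 4 (0.20 log units; within the scatter), with wide uncertainty. For compound 4 the estimate in this assay is 3000 nM, expected to fall between 1000 nM and 9000 nM.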

Compound 4, half-maximal inhibitory concentration: 15400 nM
The estimate for compound 4 lay 5.1-fold (0.71 log units) below the measured number; measured number above the stated range.
By their numbers in this assay, from the lowest: compound 2; then compound 1; then compounds 3 and 4 (each within the scatter of the next).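

In this assay the change to 2,4-dihydroxyphenyl on a carbon with a double bond to nitrogen gives an 8.1-fold higher number from compound 1 to compound 4 (0.91 log units; beyond the scatter) and so sides with the earlier step to the 4-hydroxyphenyl of compound 3, not with the step to the 2-hydroxynaphthalen-1-yl of compound 2. Putting hydroxy in place of hydrogen on an aromatic carbon of the phenyl ring gives a 2.0-fold higher number from compound 3 to compound 4 (0.30 log units; within the scatter) and so cannot be told apart from no change, while the gap to the fused aryl group is wide at a 25-fold higher number from compound 2 to compound 4 (1.40 log units; beyond the scatter) and shows that a hydroxy on the aryl group does not by itself bring the lower number, with compound 2 going against any rule that hydroxy raises it. Nothing at hand accounts for these differences.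

The compounds shown leave open whether the lower number of compound 2 belongs to the naphthalene rings or to their hydroxy, which a naphthalen-1-yl group without hydroxy would separate. They also leave open how a 2,4-dimethoxyphenyl or a 2,4-diaminophenyl group would compare at this place with the 2,4-dihydroxyphenyl and 2,4-difluorophenyl groups.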